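A few compounds are considered here, and "the series" means these few. Any claim that something is new, unique, unknown or untested is made for them only; others in the source may bear on it.

Compound 1 `CC1(C)CC(C)(C)c2cc(NC(=O)Nc3ccc(C#N)cc3)ccc2O1` and compound 2 `CCC1(CC)CC(C)(C)c2cc(NC(=O)Nc3ccc(C(F)(F)F)cc3)ccc2O1` share a core and differ in more than one place, so only their two numbers can be compared. In a functional assay on A2780 cells (Homo sapiens) for inhibition, with a stated time of 72 h, tested at 10 uM (on this read-out lower numbers stand for less inhibition of growth and higher numbers for more inhibition of growth at the one concentration tested), compound 1 gives 93%, and compound 2 gives 92.4%, the lower of the two, yet within the usual scatter of compound 1. Compound 3 `CCC1(CC)CC(C)(C)c2cc(NC(=O)Nc3ccc([N+](=O)[O-])cc3)ccc2O1` differs from compound 2 by nitro in place of trifluoromethyl on an aromatic carbon. Going by the values given here, no measured pair shows this change, so its effect is unknown; both measured compounds sit near full inhibition. The expected step is a number 3.4 percentage points lower from compound 2 to compound 3 (within the scatter), small and likely inside the scatter. The estimate for compound 3 is 89%, between 72% and 98%.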

Compound 3, percent growth inhibition at one concentration: 93.2%
Beside the measured number, compound 3's estimate is 4.2 percentage points below it, and the stated range covers the measured number.
By their numbers in this assay, from the lowest: compounds 2, 1 and 3 (each within the scatter of the next).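

In this assay nitro in place of trifluoromethyl on this aromatic carbon gives a number 0.8 percentage points higher from compound 2 to compound 3 (within the scatter) and so leaves growth inhibition unchanged as far as this read-out can tell. Going by these compounds alone, the earlier pair differed in more than one place, so this is the first direct reading of a single change at this position. No measurement shown here offers a reason for the result. Still open, on these data alone, is what an amine or a carboxylic acid at this position would give, and whether compound 2 and compound 3 would still match at lower concentrations.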